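The source may report more compounds than this note shows. Statements on the series, on what has been measured and on what is new or still open speak of the compounds shown alone.

The three measured compounds share one core and differ only in the group on the benzyl ring. Compound 1 `O=[N+]([O-])c1cccc(CSc2nnc(-c3ccc4c(c3)OCCO4)o2)c1` carries a nitro group, and in a functional assay on SW 1116 cells (Homo sapiens) for antiproliferative activity, read by MTT assay, with a stated time of 48 h (a lower number here means a stronger inhibitor, a higher number a weaker inhibitor), compound 1 gives 30100 nM. Compound 2 `Clc1ccccc1CSc1nnc(-c2ccc3c(c2)OCCO3)o1` carries a chloro group, and in this assay compound 2 gives 29500 nM. Compound 3 `O=[N+]([O-])c1ccccc1CSc1nnc(-c2ccc3c(c2)OCCO3)o1` carries a nitro group, and in this assay compound 3 gives 20800 nM. For the measured compounds named here, the only single-point step among them, nitro in place of chloro on an aromatic carbon, is a 1.4-fold lower number from compound 2 to compound 3 (0.15 log units; within the scatter), within the scatter; the gap between compound 1 and compound 3 is likewise within the scatter. Compound 3 is thus not set apart from either companion: the three numbers sit together.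

Compound 4 `c1ccc(CSc2nnc(-c3ccc4c(c3)OCCO4)o2)cc1` has not been measured. From compound 3 it differs in one place: hydrogen in place of nitro on an aromatic carbon. Going by the values given here, no measured step removes a group to leave hydrogen. Among the compounds with values here, the one step touching a nitro group, a 1.4-fold lower number from compound 2 to compound 3 (0.15 log units; within the scatter), stayed within the scatter, and compound 1 and compound 3, both nitro-bearing, also lie within the scatter of each other. The expected step, a 1.2-fold higher number from compound 3 to compound 4 (0.08 log units; within the scatter), is therefore one of no change beyond the scatter. Compound 4 is expected to give about 25000 nM in this assay, with a range from 10000 nM to 60000 nM.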

Compound 4, half-maximal inhibitory concentration: 31500 nM
Estimate against measurement, compound 4: 1.3-fold (0.10 log units) below; low and high end bracket the measured number.
By their numbers in this assay, from the lowest: compounds 3, 2, 1 and 4 (each within the scatter of the next).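

In this assay, hydrogen in place of nitro on an aromatic carbon is a 1.5-fold higher number from compound 3 to compound 4 (0.18 log units; within the scatter), and the same exchange for the nitro group of the other nitro-bearing compound is a 1.0-fold higher number from compound 1 to compound 4 (0.02 log units; within the scatter), while hydrogen in place of chloro is a 1.1-fold higher number from compound 2 to compound 4 (0.03 log units; within the scatter). The earlier compounds shown here compared only one substituent with another, whereas these steps add a comparison with hydrogen itself and show that, in these compounds, neither nitro nor chloro on this ring sets a compound apart from the one carrying hydrogen, so the group at this place, ortho to a large group, makes no difference beyond the scatter. No independent measurement bears on why these steps stay so small.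

As far as these compounds go, whether an amine, a carboxylic acid or a methoxy group on the same aromatic carbon would move the number beyond the scatter remains open. Also open, from the compounds shown here alone, is whether a longer chain in place of the benzyl group, or any change to the shared core, would separate a compound from these four.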